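Swapping Methoxy for Chloro on a Nitro-Bearing Dienone

This account rests on a few compounds, and the source may have more. Where it says the series, first, only, none or still open, it means among the compounds named here.

Compound 1, `O=C1/C(=C/c2ccc(F)cc2)CCC/C1=C\c1cccc([N+](=O)[O-])c1`, gives 5050 nM in a functional assay on CCRF-CEM cells (Homo sapiens) for cytotoxicity, with a stated time of 72 h; a lower number here means a stronger inhibitor, a higher number a weaker inhibitor. Compound 2, `COc1ccc(/C=C2\CCC/C(=C\c3cccc([N+](=O)[O-])c3)C2=O)cc1`, gives 8220 nM in this assay.

Among these two numbers compound 2 carries the higher one, though the step of a 1.6-fold higher number from compound 1 to compound 2 (0.21 log units; within the scatter) lies within the scatter, so the two compounds cannot be separated. Compound 3, `O=C1/C(=C/c2ccc(Cl)cc2)CCC/C1=C\c1cccc([N+](=O)[O-])c1`, differs from compound 2 by one change: chloro in place of methoxy on an aromatic carbon. Within the data shown here, the only measured step at this carbon is a 1.6-fold higher number from compound 1 to compound 2 (0.21 log units; within the scatter), a swap of fluoro for methoxy that stayed within the scatter, and it does not involve chloro itself. With so little to go on, the single-atom chloro group is expected to behave roughly as fluoro did in compound 1, giving 5050 nM, so the estimated step of a 1.5-fold lower number from compound 2 to compound 3 (0.17 log units; within the scatter) is small and towards a lower number. Compound 3 is therefore estimated at 5500 nM, with a range from 2200 nM to 14000 nM.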

Compound 3, half-maximal inhibitory concentration in the CCRF-CEM assay: 1750 nM
Beside the measured number, compound 3's estimate is 3.1-fold (0.50 log units) above it; measured number outside the range, below it.
By their numbers in the CCRF-CEM assay, from the lowest: compound 3; then compounds 1 and 2 (each within the scatter of the next).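

In the CCRF-CEM assay the group on this aromatic carbon turns out to matter, since chloro in place of methoxy gives a 4.7-fold lower number from compound 2 to compound 3 (0.67 log units; beyond the scatter) and chloro in place of fluoro gives a 2.9-fold lower number from compound 1 to compound 3 (0.46 log units; beyond the scatter), both beyond the scatter, whereas fluoro and methoxy could not be separated. In a physicochemical assay for lipophilicity (a higher number here means a more lipophilic compound, a lower number a more polar compound), compound 2 gives 5.06 and compound 3 gives 5.06, so the two compounds that differ in the cell assay show the same number in this read-out. Nothing available here explains why chloro stands apart from the other two groups.

From the compounds shown here alone, whether the lower number is particular to chloro, or would also appear with bromo, trifluoromethyl or an amine on this carbon, remains open. All three compounds share the rest of the core, so it is also unknown whether this step would hold with a different group in place of the nitro.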